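The compounds below may be only part of what the source reports. "The series", "measured", "known", "first", "only" and "open" are said of these compounds alone.

Of the compounds shown here, two that share one core have been tested in a functional assay on HCT-116 cells (Homo sapiens) for cytotoxicity, read by MTT assay, with a stated time of 72 h; a higher number here means a weaker inhibitor, a lower number a stronger inhibitor. Compound 1 `NS(=O)(=O)c1cc(-c2nnc(CN3CCC(Cc4ccccc4)CC3)o2)c(Cl)cc1SCc1ccccc1` gives 19000 nM in this assay. Compound 2 `NC(=O)c1cn(Cc2nnc(-c3cc(S(N)(=O)=O)c(SCc4ccccc4)cc3Cl)o2)nn1` gives 72000 nM in this assay, the higher of the two numbers; the gap to compound 1 lies beyond the usual scatter of repeated measurements, so compound 2 is the weaker of the pair. Compound 3 `NS(=O)(=O)c1cc(-c2nnc(/C=C/c3ccccc3)o2)c(Cl)cc1SCc1ccccc1` has not yet been measured. It differs from compound 2 in one place: 2-phenylethenyl in place of (4-carbamoyl-1H-1,2,3-triazol-1-yl)methyl on an aromatic carbon. An amide-bearing ring is thus exchanged for a group made of carbon only. Among the measured compounds shown here, no pair among the measured compounds isolates such a change, so the step can only be judged roughly. The step in this assay is expected to be a 2.9-fold lower number from compound 2 to compound 3 (0.46 log units; beyond the scatter), a modest lowering of the number rather than a large one. The estimate for compound 3 in this assay is 25000 nM, with a range from 8000 nM to 80000 nM.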

Compound 3, half-maximal inhibitory concentration: 18000 nM
Estimate against measurement, compound 3: 1.4-fold (0.14 log units) above, and the stated range covers the measured number.
By their numbers in this assay, from the lowest: compounds 3 and 1 (each within the scatter of the next); then compound 2.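

In this assay, the exchange of (4-carbamoyl-1H-1,2,3-triazol-1-yl)methyl for 2-phenylethenyl on this aromatic carbon gives a 4.0-fold lower number from compound 2 to compound 3 (0.60 log units; beyond the scatter), the first step measured at this position with everything else held the same. It shows that the number responds to the group placed here, though only modestly, and that a group of carbon only, with no hydrogen-bond donors or acceptors, is compatible with the lower number in this pair. No measurement at hand explains the step.

This single exchange alters the ring, the amide and the hydrogen-bond counts all at once, so the compounds shown cannot tell which of these changes matters. Also open, on these data alone, is how a saturated 2-phenylethyl chain or a carboxylic acid would behave at this position.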